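A few compounds are considered here, and "the series" means these few. Any claim that something is new, unique, unknown or untested is made for them only; others in the source may bear on it.

Measured compounds in a functional assay on A549 cells (Homo sapiens) for cytotoxicity, read by MTT assay, with a stated time of 48 h; on this read-out higher numbers stand for weaker inhibition and lower numbers for stronger inhibition:
- compound 1, `CCOC(=O)c1c(-c2cc3ccccc3oc2=O)nn(-c2cccc(Cl)c2)c1C(=O)OCC`: 28000 nM
- compound 2, `CCOC(=O)c1c(-c2cc3ccccc3oc2=O)nn(-c2ccc(Br)cc2)c1C(=O)OCC`: 100000 nM

Compound 1 gives the lowest of the two numbers in this assay; its nearest neighbour is compound 2, and the step of a 3.6-fold higher number from compound 1 to compound 2 (0.55 log units; beyond the scatter) is the only one measured in the series. That step changes the aryl group on the aromatic nitrogen, 4-bromophenyl in place of 3-chlorophenyl, and leaves the coumarin part of the core untouched.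

Compound 3, `CCOC(=O)c1c(-c2cc3ccc(OCC=C(C)C)cc3oc2=O)nn(-c2cccc(Cl)c2)c1C(=O)OCC`, is not yet measured. It keeps the 3-chlorophenyl of compound 1 and differs only at the core: (3-methylbut-2-en-1-yl)oxy in place of hydrogen on an aromatic carbon. Among the measured compounds shown here, no measured step touches this position, so the single step from compound 1 to compound 2 does not bear on it directly; it only shows that a single substituent change can move the number by a modest amount. For the measured compounds named here, with no comparable step on the fused ring, no change beyond the scatter is expected, and the estimated step of a 1.4-fold lower number from compound 1 to compound 3 (0.15 log units; within the scatter) is set close to the starting point. Compound 3 is therefore expected to come out near 20000 nM, within 5000 nM to 80000 nM.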

Compound 3, half-maximal inhibitory concentration: 163000 nM
The estimate for compound 3 lay 8.2-fold (0.91 log units) below the measured number, and the stated range ends below it.
By their numbers in this assay, from the lowest: compound 1; then compounds 2 and 3 (each within the scatter of the next).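

In this assay, among the compounds shown here, the first measured change on the fused part of the core gives a 5.8-fold higher number from compound 1 to compound 3 (0.77 log units; beyond the scatter), so this aromatic carbon does affect the read-out: with the 3-chlorophenyl held fixed, (3-methylbut-2-en-1-yl)oxy in place of hydrogen shifts the number towards weaker inhibition. The earlier compounds shown here showed a change only in the aryl group on the aromatic nitrogen, a 3.6-fold higher number from compound 1 to compound 2 (0.55 log units; beyond the scatter), whereas this result shows that the core of compound 1 also responds to substitution on the fused ring, and that both measured changes from compound 1 raise the number. No measurement on hand accounts for the rise at this position.

From the compounds shown here alone, it remains open whether the rise belongs to the oxygen attached to the aromatic carbon or to the chain beyond it, a question that a hydroxy or methoxy group on the same carbon would help to separate. Going by these compounds, it is also open whether (3-methylbut-2-en-1-yl)oxy would act in the same way with the 4-bromophenyl of compound 2, since a single step at this position cannot show whether the two changes are independent.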